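Toxicity notes: from compound 2 to compound 3

The compounds below may be only part of what the source reports. "The series", "measured", "known", "first", "only" and "open" are said of these compounds alone.

Values from a toxicity assay (LMTK cells) for cytotoxicity, with Mus musculus as the target, read by MTT assay, with a stated time of 72 h (a higher number here means a weaker inhibitor, a lower number a stronger inhibitor), are as follows.
- compound 1 `Cc1c(C)c2c(c(C)c1OC(=O)CCC(=O)O)CCC(C)(C(=O)NC1CC(C)(C)N([O])C(C)(C)C1)O2` gives > 300000 nM as a limit
- compound 2 `Cc1c(C)c2c(c(C)c1OC(=O)CCC(=O)O)CCC(C)(C(=O)NCC1CC(C)(C)N([O])C1(C)C)O2` gives > 300000 nM as a limit

In this assay compound 2 stands at > 300000 nM and this is a limit, not a number. Compound 3 `Cc1c(C)c2c(c(C)c1OC(=O)CCC(=O)NCC1CC(C)(C)N([O])C1(C)C)CCC(C)(C(=O)NCC1CC(C)(C)N([O])C1(C)C)O2` is not yet measured. It carries, in place of the hydroxy on a carbonyl carbon, a group with one five-membered non-aromatic ring with 1 hetero atom. Counted, the change is a group of 12 heavy atoms (9 carbon, 2 nitrogen, 1 oxygen; one five-membered non-aromatic ring with 1 hetero atom) in place of one oxygen atom, on a carbonyl carbon and nothing else differs.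

Going by the values given here, the only measured step is a step that the two limits leave unreadable from compound 1 to compound 2 and it falls on an amide-type nitrogen, not at this place. The series offers the limit of > 300000 nM in this assay, at which 2 of the 2 values shown sit, and no readable step size. With compound 2 at > 300000 nM as a limit, no step beyond the scatter is expected in this assay in either direction. The expected change is a number no higher from compound 2 to compound 3 (the limit leaves the size open) and it is only an estimate. For compound 3 the estimated value is 300000 nM with an expected range of 100000 nM to 600000 nM and a further limit is the likeliest report.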

Compound 3, half-maximal inhibitory concentration: > 300000 nM
Compound 3: a limit, no number (the forecaster's own chance of this, stated with the estimate: 70%); the middle value lies on the limit itself.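

In this assay compound 3 gives > 300000 nM as a limit and not a number, so no step can be read from compound 2 to compound 3. The compounds shown leave open what value any of them would reach in this test, since all stop at one limit: the limit of > 300000 nM in this assay, at which 3 of the 3 values shown sit.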